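The compounds below may be only part of what the source reports. "The series", "measured", "known", "first", "only" and "open" are said of these compounds alone.

Among the compounds with values here, compound 1 `O=C1NCCN(c2cccc(F)c2)N1` is one of two compounds measured in an assay on RBL-1 cells for inhibition of Polyunsaturated fatty acid 5-lipoxygenase (Rattus norvegicus) (on this read-out lower numbers stand for stronger inhibition and higher numbers for weaker inhibition), where compound 1 gives 19000 nM, the higher of the two numbers. Compound 2 `CC1CN(c2cccc(F)c2)NC(=O)N1` gives 6300 nM in this assay, a step of a 3.0-fold lower number from compound 1 to compound 2 (0.48 log units; beyond the scatter) that concerns the saturated part of the shared core. Compound 3 `O=C1NCCN(c2cccc(-c3ccccn3)c2)N1` carries pyridin-2-yl in place of fluoro on an aromatic carbon. Within the data shown here, no measured step touches the aromatic ring, so the only step in hand does not bear on this change, and no direction beyond the scatter can be read from it. Compound 3 is therefore expected to stand near compound 1, with a step of a 1.9-fold lower number from compound 1 to compound 3 (0.28 log units; within the scatter), giving an estimate of 10000 nM with a range from 1500 nM to 60000 nM.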

Compound 3, half-maximal inhibitory concentration: 30000 nM
Estimate against measurement, compound 3: 3.0-fold (0.48 log units) below; the measured number falls inside the stated range.
By their numbers in this assay, from the lowest: compound 2; then compounds 1 and 3 (each within the scatter of the next).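

Within the data shown here, replacing fluoro with pyridin-2-yl on this aromatic carbon gives a 1.6-fold higher number from compound 1 to compound 3 (0.20 log units; within the scatter) in this assay and is the only measured change on the aromatic ring. Fluoro and the much larger pyridin-2-yl, which brings a six-membered aromatic ring, therefore cannot be told apart on this read-out. Nothing available explains this result. On these data alone, whether an amine or a carboxylic acid on this aromatic carbon would move the number beyond the scatter remains open. So does how pyridin-2-yl would behave on the methyl-bearing core of compound 2.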